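Piperazine substituent changes in a cytotoxicity series

The source may hold more compounds than are shown below. What is called first, only, known or untested is meant among the compounds shown, and "the series" means these compounds.

Measured compounds:
compound 1 `CN(C)/C=C/N1CCN(CC(=O)Nc2ccc(-c3nc(-c4ccccc4)c(-c4ccccc4)n3C)cc2)CC1` gives 80 ug/mL in a functional assay on HT-29 cells (Homo sapiens) for cytotoxicity, read by MTT assay, with a stated time of 24 h; a higher number here means a weaker inhibitor, a lower number a stronger inhibitor;
compound 2 `Cn1c(-c2ccc(NC(=O)CN3CCN(c4ccccc4)CC3)cc2)nc(-c2ccccc2)c1-c1ccccc1` gives 8.6 ug/mL.

Compound 2 stands lowest of the two numbers; its nearest neighbour is compound 1, and the step of a 9.3-fold lower number from compound 1 to compound 2 (0.97 log units; beyond the scatter) is the only one known. Compound 3 `Cc1ccc(CN2CCN(CC(=O)Nc3ccc(-c4nc(-c5ccccc5)c(-c5ccccc5)n4C)cc3)CC2)cc1` differs from compound 2 by 4-methylbenzyl in place of phenyl on an amine nitrogen in a ring. That earlier step swapped a chain for an aromatic ring; none swaps one aromatic group for another, so nothing measured bears directly on this change. A step of modest size at most, in either direction or none beyond the scatter, is expected, a 1.2-fold higher number from compound 2 to compound 3 (0.07 log units; within the scatter). Compound 3 is estimated at 10 ug/mL, within 3 ug/mL to 30 ug/mL.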

Compound 3, half-maximal inhibitory concentration: 62 ug/mL
The estimate for compound 3 lay 6.2-fold (0.79 log units) below the measured number; measured number outside the range, above it.
By their numbers in this assay, from the lowest: compound 2; then compounds 3 and 1 (each within the scatter of the next).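

Swapping one aromatic group for another at this ring nitrogen is not a neutral change: in this assay it gives a 7.2-fold higher number from compound 2 to compound 3 (0.86 log units; beyond the scatter) as its step. An aromatic ring alone therefore does not go with the low number of compound 2, since a 1.3-fold lower number from compound 1 to compound 3 (0.11 log units; within the scatter) links the 4-methylbenzyl compound to the one with the open chain. Nothing measured here explains this difference.

From the compounds shown here alone, whether the methyl or the carbon link of 4-methylbenzyl matters remains open. Unsubstituted benzyl and 4-methylphenyl on this nitrogen would separate the two.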